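The source may report more compounds than this note shows. Statements on the series, on what has been measured and on what is new or still open speak of the compounds shown alone.

Measured compounds:
compound 1 `CC(C)(C)OC(=O)CCC[N+]1(C)CCc2c(sc(NC(=O)Nc3ccc(Cl)cc3)c2C(N)=O)C1` gives 250 nM
compound 2 `NC(=O)c1c(NC(=O)Nc2ccc(Cl)cc2)sc2c1CCN(CC1CCCC1)C2` gives 1830 nM
compound 3 `CC(C)N1CCc2c(sc(NC(=O)Nc3ccc(Cl)cc3)c2C(N)=O)C1` gives 1490 nM

In a functional assay (strain AB) with Danio rerio as the target, read by microscopy, with a stated time of 1 h (a lower number here means that less compound is needed, a higher number that more compound is needed for the effect), compound 1 stands lowest of the three numbers. Compound 3 is the nearest to it and compound 2 the furthest, and both of those gaps lie beyond the scatter, so compound 1 needs clearly less compound than either.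

Compound 4 `CC(C)C[N+]1(C)CCc2c(sc(NC(=O)Nc3ccc(Cl)cc3)c2C(N)=O)C1` differs from compound 1 in a single place: isopropyl in place of 2-(tert-butoxycarbonyl)ethyl on a saturated chain carbon bound to an amine nitrogen in a ring. Within the data shown here, the only measured step that changes a substituent on the ring nitrogen is a 1.2-fold lower number from compound 2 to compound 3 (0.09 log units; within the scatter), which lay within the scatter. Among the measured compounds shown here, that step, however, was taken between two compounds that carry an uncharged ring nitrogen, whereas compound 1 and compound 4 both carry the methylated, charged ring nitrogen; no measured pair isolates the exchange of the tert-butoxycarbonyl-bearing chain alone. For the measured compounds named here, since the one comparable exchange of nitrogen substituents moved the number little, a step of similar, small size is expected for a 2.0-fold higher number from compound 1 to compound 4 (0.30 log units; within the scatter), most likely a mild rise toward the numbers of compound 2 and compound 3, but not a large one. Compound 4 is therefore estimated at 500 nM in this assay, with a range from 150 nM to 1600 nM.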

Compound 4, half-maximal effective concentration: 380 nM
For compound 4 the middle estimate is 1.3-fold (0.12 log units) above the measured one, and the stated range covers the measured number.
By their numbers in this assay, from the lowest: compounds 1 and 4 (each within the scatter of the next); then compounds 3 and 2 (each within the scatter of the next).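

On a saturated chain carbon bound to the methylated ring nitrogen, the exchange of 2-(tert-butoxycarbonyl)ethyl for isopropyl replaces 9 heavy atoms with 3 and removes both hydrogen-bond acceptors and the double bond outside aromatic rings, yet the step in this assay stays within the scatter (a 1.5-fold higher number from compound 1 to compound 4 (0.18 log units; within the scatter)). For this pair, then, the tert-butoxycarbonyl group is not required for a number in this range, and the position accepts a much smaller substituent; the earlier step (a 1.2-fold lower number from compound 2 to compound 3 (0.09 log units; within the scatter)) had shown a similarly small effect only for compounds without the methyl group on the ring nitrogen. The information at hand offers no explanation for this result.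

Whether the methyl group on the ring nitrogen itself accounts for the lower numbers of compound 1 and compound 4 stays open, as the compounds shown include no pair that differs only in that group. Also open, as far as these compounds go, is how a carboxylic acid, an amine or a longer chain in place of 3-(tert-butoxycarbonyl)propyl would read in this assay.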